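Thiazolyl replacement on the cyclopropyl carbon of compound 3

The compounds below may be only part of what the source reports. "The series", "measured", "known", "first", "only" and "open" are said of these compounds alone.

Compound 3 `CC[C@H](C)[C@H](N)CN(C(=O)[C@@H]1C[C@H]1c1c(F)cccc1F)c1ccc(-c2ccccc2)cc1` stands highest of the two numbers in a functional assay for agonist activity at G protein-coupled receptor 88 (Homo sapiens), read by HTRF and cAMP accumulation; a lower number here means that less compound is needed, a higher number that more compound is needed for the effect: compound 3 gives 11000 nM. Its nearest neighbour is compound 2 `CC[C@H](C)[C@H](N)CN(C(=O)[C@@H]1C[C@H]1c1cc(F)ccc1F)c1ccc(-c2ccccc2)cc1`, which gives 770 nM. The separation is a 14-fold higher number from compound 2 to compound 3 (1.15 log units; beyond the scatter). Compound 1 `CC[C@H](C)[C@H](N)CN(C(=O)[C@@H]1C[C@H]1c1ccc(OC)cc1)c1ccc(-c2ccccc2)cc1` reaches only the limit of this assay, reported as > 25000 nM. The group on the saturated ring carbon therefore weighs heavily in this assay, seen in an at least 32-fold lower number from compound 1 to compound 2 (1.51 log units; beyond the scatter) and an at least 2.2-fold lower number from compound 1 to compound 3 (0.35 log units; beyond the scatter). Compound 4 `CC[C@H](C)[C@H](N)CN(C(=O)[C@@H]1C[C@H]1c1ncc(C)s1)c1ccc(-c2ccccc2)cc1` carries 5-methyl-1,3-thiazol-2-yl in place of 2,6-difluorophenyl on a saturated ring carbon. Within the data shown here, no measured step exchanges the six-membered aromatic ring of carbon only for a five-membered aromatic ring with hetero atoms, so the direction is open, and the measured steps show that a large move either way is possible. The estimate for compound 4 is 6000 nM, range 800 nM to 30000 nM. The expected step is a 1.8-fold lower number from compound 3 to compound 4 (0.26 log units; within the scatter).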

Compound 4, half-maximal effective concentration: 1300 nM
Estimate against measurement, compound 4: 4.6-fold (0.66 log units) above, within the range that was stated.
By their numbers in this assay, from the lowest: compounds 2 and 4 (each within the scatter of the next); then compound 3. At a limit, above all of these: compound 1.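

In this assay, a five-membered aromatic ring with hetero atoms is accepted on the saturated ring carbon: an 8.5-fold lower number from compound 3 to compound 4 (0.93 log units; beyond the scatter), while a 1.7-fold higher number from compound 2 to compound 4 (0.23 log units; within the scatter), which leaves 5-methyl-1,3-thiazol-2-yl level with 2,5-difluorophenyl. A six-membered aromatic ring of carbon only is therefore not needed at this position, and the comparison with 4-methoxyphenyl gives an at least 19-fold lower number from compound 1 to compound 4 (1.28 log units; beyond the scatter). The value for compound 1 is a limit, so that step has only a bound: the limit of > 25000 nM in this assay, at which 1 of the 4 values shown sits.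

Open, going by these compounds, is whether the methyl or the ring hetero atoms account for the step from 2,6-difluorophenyl. An unsubstituted thiazol-2-yl or a pyridin-2-yl group would separate the two.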